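A few compounds are considered here, and "the series" means these few. Any claim that something is new, unique, unknown or untested is made for them only; others in the source may bear on it.

Measured compounds:
Compound 1 `COc1nc(N)nc2c1c(-c1ccccc1)cn2[C@@H]1O[C@H](CO)[C@@H](O)[C@H]1O` gives > 20000 nM in a functional assay on HeLa S3 cells (Homo sapiens) for antiproliferative activity, read by XTT assay, with a stated time of 72 h; on this read-out higher numbers stand for weaker inhibition and lower numbers for stronger inhibition.
Compound 2 `COc1ncnc2c1c(-c1ccccc1)cn2[C@@H]1O[C@H](CO)[C@@H](O)[C@H]1O` gives > 20000 nM in this assay.
Compound 3 `O=c1[nH]cnc2c1c(-c1ccccc1)cn2[C@@H]1O[C@H](CO)[C@@H](O)[C@H]1O` gives > 20000 nM in this assay.

Each of these three values is a limit of the assay rather than a number. For compound 1 the value is a limit. For compound 2 the value is a limit. For compound 3 the value is a limit. The change from compound 2 to compound 1 is amino in place of hydrogen on an aromatic carbon, and the step it made, a step that the two limits leave unreadable from compound 2 to compound 1, cannot be read, since both ends sit at the limit of > 20000 nM in this assay, at which 3 of the 3 values shown sit. The difference between the cores of compound 3 and compound 2 is not broken down here.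

Compound 4 `Nc1nc2c(c(-c3ccccc3)cn2[C@@H]2O[C@H](CO)[C@@H](O)[C@H]2O)c(=O)[nH]1` has not yet been measured. It differs from compound 3 by amino in place of hydrogen on an aromatic carbon, the same kind of change as from compound 2 to compound 1, though here the position is meta to a group of 1 heavy atom rather than meta to a methoxy group (2 heavy atoms). Given that compound 3 gives > 20000 nM and that the matching change left compound 1 at the limit of > 20000 nM in this assay, at which 3 of the 3 values shown sit, compound 4 is expected to show a step that the limit leaves unreadable from compound 3 to compound 4, so compound 4 is estimated at 40000 nM, with a range from 10000 nM to 150000 nM.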

Compound 4, half-maximal inhibitory concentration: > 20000 nM
Compound 4: a limit, no number (the forecaster's own chance of this, stated with the estimate: 85%); the middle value lies beyond the limit too.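

In this assay, among the compounds shown here, compound 4 gives > 20000 nM, a limit of the assay and not a number, so no step from compound 3 to compound 4 can be read. The compounds shown leave open what amino in place of hydrogen on an aromatic carbon does to activity in this assay, since every value is a limit: the limit of > 20000 nM in this assay, at which 4 of the 4 values shown sit.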